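The source may report more compounds than this note shows. Statements on the series, on what has been measured and on what is new or still open speak of the compounds shown alone.

Compound 1 `O=C(O)c1cn(Cc2ccc(-n3cccn3)cc2)c2cc(NC[C@H]3CCNC3)c(F)cc2c1=O` gives 187000 nM in an assay on isolated protein for inhibition of DNA topoisomerase 1 (Homo sapiens), with a stated time of 15 min; a higher number here means a weaker inhibitor, a lower number a stronger inhibitor.
Compound 2 `O=C(O)c1cn(Cc2ccc(-n3cccn3)cc2)c2cc(NC[C@@H]3CCNC3)c(F)cc2c1=O` gives 200000 nM in this assay.
Compound 3 `NC[C@@H]1CCN(c2cc3c(cc2F)c(=O)c(C(=O)O)cn3Cc2ccc(-n3cccn3)cc2)C1` gives 91600 nM in this assay.

Compound 3 has the lowest number of the three, though only by a modest margin: the step is a 2.0-fold lower number from compound 1 to compound 3 (0.31 log units; beyond the scatter) and a 2.2-fold lower number from compound 2 to compound 3 (0.34 log units; beyond the scatter). Compounds 1 and 2 differ only in the configuration as drawn (the fact that compounds 1 and 2 differ only in the configuration as drawn), and their numbers sit within the scatter of each other a 1.1-fold higher number from compound 1 to compound 2 (0.03 log units; within the scatter).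

Compound 4 `O=C(O)c1cn(Cc2ccc(-n3cccn3)cc2)c2cc(N3C[C@H]4CCNC[C@H]4C3)c(F)cc2c1=O` is not yet measured. It differs from compound 3 at the same ring position that was changed before: a group of 9 heavy atoms (7 carbon, 2 nitrogen; one five-membered non-aromatic ring with 1 hetero atom, one six-membered non-aromatic ring with 1 hetero atom) in place of a group of 7 heavy atoms (5 carbon, 2 nitrogen; one five-membered non-aromatic ring with 1 hetero atom), on an aromatic carbon, on the aromatic carbon ortho to a fluoro group. The entering group keeps one hydrogen-bond donor and two acceptors, but adds a second, six-membered, non-aromatic ring fused to the five-membered one. For the measured compounds named here, the only steps at this position, from compounds 1 and 2 to compound 3, were modest, so a change of similar size or none beyond the scatter is the reasonable expectation in this assay. Compound 4 is therefore estimated at 70000 nM, within 20000 nM to 250000 nM, an expected step of a 1.3-fold lower number from compound 3 to compound 4 (0.12 log units; within the scatter).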

Compound 4, half-maximal inhibitory concentration: 31300 nM
Compound 4: the middle estimate sits 2.2-fold (0.35 log units) above what was measured; the range from low to high includes it.
By their numbers in this assay, from the lowest: compound 4; then compound 3; then compounds 1 and 2 (each within the scatter of the next).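

Adding a six-membered non-aromatic ring fused to the five-membered one goes with a further drop at this position in this assay: a 2.9-fold lower number from compound 3 to compound 4 (0.47 log units; beyond the scatter). Against the two compounds joined through the ((pyrrolidin-3-yl)methyl)amino group, the steps are a 6.4-fold lower number from compound 2 to compound 4 (0.81 log units; beyond the scatter) and a 6.0-fold lower number from compound 1 to compound 4 (0.78 log units; beyond the scatter), so this position can shift the number further than the earlier steps alone showed. Nothing at hand explains why the fused rings go with the lower number.

The compounds shown do not tell whether the second ring itself or the particular arrangement of its two defined stereocentres matters. The mirror-image form of compound 4 could address the arrangement, and a single-ring piperazine or a fused pair with a seven-membered ring in place of the six-membered one could test how much the ring matters.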